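Lengthening the sulfanyl chain of compound 2

The source may hold more compounds than are shown below. What is called first, only, known or untested is meant among the compounds shown, and "the series" means these compounds.

Compound 1 `Cc1nc(N)c2nc(O)n(Cc3ccccc3)c2n1` gives 1 uM in a functional assay (spleen, spleen) for activation, with Mus musculus as the target; on this read-out higher numbers stand for an effect only at larger amounts of compound and lower numbers for an effect already at smaller amounts.
Compound 2 `CCSc1nc(N)c2nc(O)n(Cc3ccccc3)c2n1` gives 0.1 uM in this assay.
Compound 3 `CCNc1nc(N)c2nc(O)n(Cc3ccccc3)c2n1` gives 1 uM in this assay.

Compound 2 stands lowest of the three numbers: there is a 10-fold lower number from compound 1 to compound 2 (1.00 log units; beyond the scatter) and a 10-fold higher number from compound 2 to compound 3 (1.00 log units; beyond the scatter), both beyond the scatter. Compound 4 `CCCCCSc1nc(N)c2nc(O)n(Cc3ccccc3)c2n1` differs from compound 2 by propyl in place of hydrogen on a saturated chain carbon, two bonds along the chain from a sulfur. For the measured compounds named here, no measured step bears directly on this change; the two steps that exist each exchange the group on the aromatic carbon rather than lengthen a chain, so they give no guide to direction or size. With nothing pointing either way, compound 4 is expected to stay within the scatter of compound 2, with no change at the digits printed from compound 2 to compound 4 (within the scatter) as the estimated step. In this assay compound 4 is therefore estimated at 0.1 uM, in a range from 0.02 uM to 0.5 uM.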

Compound 4, minimum effective concentration: 10 uM
The estimate for compound 4 lay 100-fold (2.00 log units) below the measured number; measured number above the stated range.
By their numbers in this assay, from the lowest: compound 2; then compounds 1 and 3 (each within the scatter of the next); then compound 4.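

In this assay, chain length on the sulfanyl group proves decisive, with a 100-fold higher number from compound 2 to compound 4 (2.00 log units; beyond the scatter). Sulfur on this aromatic carbon therefore does not by itself secure a low number, as the pentylsulfanyl group also compares poorly with methyl and ethylamino, with a 10-fold higher number from compound 1 to compound 4 (1.00 log units; beyond the scatter) and a 10-fold higher number from compound 3 to compound 4 (1.00 log units; beyond the scatter). No available measurement accounts for this loss.

The compounds shown leave open how a propylsulfanyl or butylsulfanyl group would read, and so whether the number climbs steadily with chain length or jumps at one point. As far as these compounds go, a methylsulfanyl group and a branched sulfanyl chain remain equally open.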